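A few compounds are considered here, and "the series" means these few. Any claim that something is new, unique, unknown or untested is made for them only; others in the source may bear on it.

Compound 3, `N#CCCn1cnc2c(Br)c(Br)c(Br)c(Br)c21`, gives 2% in a functional assay on CCRF-CEM cells (Homo sapiens) for cytotoxicity, read by MTT assay, with a stated time of 24 h, tested at 50 uM (a higher number here means a weaker effect of the compound at the concentration tested, a lower number a stronger effect), the same number at the digits shown as compound 1, `Cc1nc2c(Br)c(Br)c(Br)c(Br)c2n1CC#N`, which gives 2%; together these two sit lowest among the three measured compounds, while compound 2, `Cc1nc2c(Br)c(Br)c(Br)c(Br)c2n1CCCCC#N`, gives 55%. For the measured compounds named here, the one step measured so far is a number 53 percentage points higher from compound 1 to compound 2 (beyond the scatter), and it concerns the chain on the ring nitrogen, not the aromatic carbon that compound 4, `Cc1nc2c(Br)c(Br)c(Br)c(Br)c2n1CCC#N`, changes: methyl in place of hydrogen on an aromatic carbon. Going by the values given here, no measured step bears directly on this change. Compound 1 carries the methyl group and still gives a low number, so the methyl alone does not appear to lift the read-out. Compound 4 is therefore expected to stay close to compound 3, with a number 2 percentage points higher from compound 3 to compound 4 (within the scatter), an estimate of 4% within 0% to 20%.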

Compound 4, a percentage reported as activity, at one concentration (the size of the read-out at that concentration, not a potency): 2%
Beside the measured number, compound 4's estimate is 2 percentage points above it, within the range that was stated.
By their numbers in this assay, from the lowest: compounds 1, 3 and 4 (each within the scatter of the next); then compound 2.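

In this assay, methyl in place of hydrogen on the aromatic carbon between two ring nitrogen atoms now has a direct reading, and the number stays put (no change at the digits printed from compound 3 to compound 4 (within the scatter)). With that methyl present, the chain on the ring nitrogen is what separates these compounds: the shorter chains match (no change at the digits printed from compound 1 to compound 4 (within the scatter)), while the longest stands apart (a number 53 percentage points lower from compound 2 to compound 4 (beyond the scatter)). No evidence here explains these numbers. Still open, going by these compounds, is whether a group larger than methyl on that carbon, such as a phenyl ring, would leave the number unchanged, and whether an amine or carboxylic acid could replace the nitrile at the chain end.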